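Working notes: removing piperidin-1-yl from compound 1

A few compounds are considered here, and "the series" means these few. Any claim that something is new, unique, unknown or untested is made for them only; others in the source may bear on it.

- Compound 1 `Cc1ccc(-c2nc3ccccc3s2)cc1NC(=O)c1cc([N+](=O)[O-])c(N2CCCCC2)cc1Cl` gives > 25000 nM
- Compound 2 `O=C(Nc1ccccc1-c1nc2ccccc2s1)c1cc([N+](=O)[O-])ccc1Cl` gives > 27000 nM

In an ADME assay on HEK293 cells (Homo sapiens) for cytotoxicity, with a stated time of 72 h (a higher number here means that more compound is needed for the effect, a lower number that less compound is needed), compound 1 gives > 25000 nM and this is a limit of the assay, not a number. Compound 2 gives > 27000 nM and this is also a limit. Going by the values given here, compound 1 therefore has no numerical position, and no measured pair differing in one place is available to size a step.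

Compound 3 `Cc1ccc(-c2nc3ccccc3s2)cc1NC(=O)c1cc([N+](=O)[O-])ccc1Cl` has hydrogen in place of piperidin-1-yl on an aromatic carbon, ortho to a nitro group and meta to a chloro group. The counted change is hydrogen in place of piperidin-1-yl on an aromatic carbon and it is the only difference considered here.

No step beyond the scatter is expected in this assay, and no direction is favoured. This expectation rests on the limit of compound 1 at > 25000 nM and on the absence of any measured number in the series. For compound 3 the expected value is 30000 nM with an estimated range from 12000 nM to 60000 nM overall. The estimate corresponds to an expected step that the limit leaves unreadable from compound 1 to compound 3 in this series, and another report as a limit is likely.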

Compound 3, half-maximal effective concentration: > 14000 nM
Compound 3: only a limit was reported; the forecaster's own chance of this, stated with the estimate: 75%; the middle value does not contradict the limit.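

In this assay compound 3 gives > 14000 nM, which is a limit of the assay. Compound 1 gives > 25000 nM, which is also a limit. Going by these compounds alone, no step between compound 1 and compound 3 can be read from these two limits. The compounds shown leave open whether hydrogen in place of piperidin-1-yl changes the half-maximal effective concentration in this assay, and in which direction.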